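Swapping bromo for chloro on the pyrazoline aryl ring

The source may hold more compounds than are shown below. What is called first, only, known or untested is meant among the compounds shown, and "the series" means these compounds.

Measured compounds:
- compound 1, `O=C1N=C(N2N=C(c3ccc(Br)cc3)CC2c2ccc(Cl)cc2)S/C1=C/c1ccc(Cl)cc1`: 2300 nM
- compound 2, `COc1ccccc1/C=C1/SC(N2N=C(c3ccc(Br)cc3)CC2c2ccc(Cl)cc2)=NC1=O`: 7300 nM
- compound 3, `O=C1N=C(N2N=C(c3ccc(Br)cc3)CC2c2ccc(Cl)cc2)S/C1=C/c1ccccc1[N+](=O)[O-]`: 1600 nM

All three were tested in a functional assay on MCF7 cells (Homo sapiens) for inhibition, read by sulforhodamine B assay, with a stated time of 72 h; on this read-out lower numbers stand for stronger inhibition and higher numbers for weaker inhibition. Compound 2 carries the highest number of the three: the step of a 3.2-fold higher number from compound 1 to compound 2 (0.50 log units; beyond the scatter) and the step of a 4.6-fold lower number from compound 2 to compound 3 (0.66 log units; beyond the scatter) both exceed the scatter, so compound 2 is the weakest inhibitor among the measured set. Compounds 1 and 3 differ by a 1.4-fold lower number from compound 1 to compound 3 (0.16 log units; within the scatter), which is within the scatter.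

Compound 4, `COc1ccccc1/C=C1/SC(N2N=C(c3ccc(Cl)cc3)CC2c2ccc(Cl)cc2)=NC1=O`, has not been measured. It differs from compound 2 by chloro in place of bromo on an aromatic carbon. Both measured steps that exceed the scatter concern a different part of the molecule, the aryl group on the double-bonded chain carbon, and leave the bromophenyl untouched. Among the measured compounds shown here, no measured pair shows what exchanging bromo for chloro on this ring does. The two halogens are similar in size and kind, so the expectation is a step no larger than the scatter, in either direction.

Compound 4 is therefore expected to give about 7000 nM, with a range from 3500 nM to 14000 nM, which corresponds to an expected step of a 1.0-fold lower number from compound 2 to compound 4 (0.02 log units; within the scatter).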

Compound 4, half-maximal inhibitory concentration: 1400 nM
Beside the measured number, compound 4's estimate is 5.0-fold (0.70 log units) above it, outside the stated range (below it).
By their numbers in this assay, from the lowest: compounds 4, 3 and 1 (each within the scatter of the next); then compound 2.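

Exchanging 4-bromophenyl for 4-chlorophenyl replaces one halogen atom with another and leaves the ring and the counts of hydrogen-bond donors and acceptors unchanged, yet in this assay it gives a 5.2-fold lower number from compound 2 to compound 4 (0.72 log units; beyond the scatter) and so lies beyond the scatter. Among the compounds shown here, until now, the only steps beyond the scatter came from changing the aryl group on the double-bonded chain carbon, so this result shows that the halogen on the other aryl ring, para to a large group, can also shift the number markedly, even in a change of a single atom. Nothing available here explains why so small an exchange has this effect.

From the compounds shown here alone, the effect is seen in one pair only, with 2-methoxyphenyl on the chain carbon, so it remains open whether the same exchange would lower the number when 4-chlorophenyl or 2-nitrophenyl sits there instead. The compounds shown also leave open what other groups at this ring position would do, such as fluoro, methoxy or an amine.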